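Swapping the Chain Nitrile for an Acetyl Group

The source may report more compounds than this note shows. Statements on the series, on what has been measured and on what is new or still open speak of the compounds shown alone.

Compound 1, `CCc1cc(C(C)=O)c(O)cc1OCCCCCCC#N`, in an assay on isolated protein for inhibition of leukotriene B4 receptor 1 (Homo sapiens), tested at 10 uM (a lower number here means less inhibition, a higher number more inhibition at the concentration tested (going by the name of the read-out)), gives 103%.
Compound 2, `COCc1cc(C(C)=O)c(O)cc1OCCCCCCC#N`, gives 47%.
Compound 3, `C=CCc1cc(C(C)=O)c(O)cc1OCCCCCCC#N`, gives 97%.

Compound 3 stands second highest of the three: compound 1 sits within the scatter of it, as a number 6 percentage points lower from compound 1 to compound 3 (within the scatter) shows, while compound 2 lies far below, as a number 50 percentage points higher from compound 2 to compound 3 (beyond the scatter) shows. Compound 4, `C=CCc1cc(C(C)=O)c(O)cc1OCCCCCC(C)=O`, differs from compound 3 by acetyl in place of cyanomethyl on a saturated chain carbon, five bonds along the chain from an oxygen on an aromatic ring. Among the compounds with values here, all three measured steps, including a number 56 percentage points lower from compound 1 to compound 2 (beyond the scatter), alter the group on the saturated chain carbon bound to an aromatic carbon; none touches the chain end, so no measured step bears directly on this change. Both groups carry one hydrogen-bond acceptor and no charge. For compound 4 a small drop at most is expected, a number 12 percentage points lower from compound 3 to compound 4 (beyond the scatter). Compound 4 is estimated at 85%, between 55% and 105%.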

Compound 4, a percentage reported as inhibition, at one concentration (the size of the read-out at that concentration, not a potency): 98%
Estimate against measurement, compound 4: 13 percentage points below; the measured number falls inside the stated range.
By their numbers in this assay, from the lowest: compound 2; then compounds 3, 4 and 1 (each within the scatter of the next).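

Within the data shown here, this is the first measured change at the chain end: acetyl in place of cyanomethyl gives a number 1 percentage points higher from compound 3 to compound 4 (within the scatter) in this assay. With the vinyl-bearing side chain of compound 3 in place, the nitrile is therefore not needed to keep inhibition this high, at least when acetyl replaces it. Nothing at hand explains why the two groups read alike.

A single test concentration gives no potency, so a gap in potency could remain hidden. As far as these compounds go, whether a carboxylic acid, an amine or a longer chain at this end would hold up equally well stays open.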